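The source may hold more compounds than are shown below. What is called first, only, known or untested is meant among the compounds shown, and "the series" means these compounds.

Compound 1 `CC1=CCCC(C)(C)C1/C=C/C(=O)/C=C/c1ccccc1F` and compound 2 `CC1=CCCC(C)(C)C1/C=C/C(=O)/C=C/c1cc(C(F)(F)F)ccc1F` share one core, while compound 3 `CC1=C(/C=C/C(=O)/C=C/c2ccccc2)C(C)(C)CCC1O` and compound 4 `CC1=C(/C=C/C(=O)/C=C/c2ccc(C(F)(F)F)cc2)C(C)(C)CCC1O` share another; how the two cores differ is not broken down here. In a functional assay on LNCaP cells (Homo sapiens) for cytotoxicity, read by MTT assay, with a stated time of 72 h (on this read-out higher numbers stand for weaker inhibition and lower numbers for stronger inhibition), compound 1 gives 1600 nM, compound 2 gives 1700 nM, and compound 3 gives 5800 nM. Compound 2 differs from compound 1 by trifluoromethyl in place of hydrogen on an aromatic carbon, and this gave a 1.1-fold higher number from compound 1 to compound 2 (0.03 log units; within the scatter). Compound 4 differs from compound 3 by trifluoromethyl in place of hydrogen on an aromatic carbon; this is the same kind of change, though here the group sits para to a large group rather than meta to a large group and para to a fluoro group. Because the earlier step was a 1.1-fold higher number from compound 1 to compound 2 (0.03 log units; within the scatter), the step from compound 3 to compound 4 is expected to be a 1.1-fold lower number from compound 3 to compound 4 (0.02 log units; within the scatter). Compound 4 is therefore estimated at 5500 nM, between 2500 nM and 12000 nM.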

Compound 4, half-maximal inhibitory concentration: 3000 nM
Beside the measured number, compound 4's estimate is 1.8-fold (0.26 log units) above it; measured number inside the range.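

In this assay, putting trifluoromethyl in place of hydrogen on an aromatic carbon gave a 1.9-fold lower number from compound 3 to compound 4 (0.29 log units; within the scatter) on the second core. This does not show that the change has no effect in general, since only two pairs are shown and the group sits at a different place in each. What it does show is that these two pairs give no sign that the two cores respond differently to this change: the same change on two cores in this assay, a 1.1-fold higher number (0.03 log units; within the scatter) from compound 1 to compound 2 and a 1.9-fold lower number (0.29 log units; within the scatter) from compound 3 to compound 4, 2.1-fold (0.31 log units) apart, within the scatter of two such steps

The compounds shown leave open whether a different group on the same aromatic carbon, such as an amine or a carboxylic acid, would carry over between the cores in the same way. They also leave open how trifluoromethyl would behave on any further core.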